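The source may hold more compounds than are shown below. What is called first, only, known or untested is meant among the compounds shown, and "the series" means these compounds.

Going by the values given here, compound 2 `Cc1cc(C)n2nc(N(C)CCN(C)C)c(S(=O)(=O)c3ccccc3)c2n1` is one of two compounds measured so far in a functional assay on HEK293 cells for antagonist activity at 5-hydroxytryptamine receptor 6 (Homo sapiens), read by cAMP accumulation, with a stated time of 2 h (on this read-out lower numbers stand for stronger inhibition and higher numbers for weaker inhibition), where compound 2 gives 489 nM. Among the compounds with values here, its number is the smaller of the two on record, yet the only comparison available, a 1.6-fold lower number from compound 1 to compound 2 (0.19 log units; within the scatter), is within the usual scatter, so compound 2 and compound 1 `Cc1cc(C)n2nc(NCCCN(C)C)c(S(=O)(=O)c3ccccc3)c2n1` cannot be separated on this read-out; in this assay compound 1 gives 764 nM.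

The next compound, compound 3 `Cc1cc(C)n2nc(N3CCNCC3)c(S(=O)(=O)c3ccccc3)c2n1`, changes the same part of the shared core. In words: piperazin-1-yl in place of (2-(dimethylamino)ethyl)(methyl)amino on an aromatic carbon. Within the data shown here, the one measured step bearing on this position, the reshaping of the amine chain from compound 1 to compound 2, gave only a small movement, a 1.6-fold lower number from compound 1 to compound 2 (0.19 log units; within the scatter), which does not reach beyond the scatter. With nothing more to go on, the expected step of a 1.4-fold higher number from compound 2 to compound 3 (0.16 log units; within the scatter) in this assay is also small and could go either way. On that basis compound 3 is estimated at 700 nM, expected to fall between 250 nM and 2000 nM.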

Compound 3, inhibition constant: 1380 nM
Compound 3: the middle estimate sits 2.0-fold (0.29 log units) below what was measured; the measured number falls inside the stated range.
By their numbers in this assay, from the lowest: compounds 2, 1 and 3 (each within the scatter of the next, the first and the last beyond it).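

In this assay, this position now shows its first step beyond the usual scatter: putting the piperazin-1-yl ring in place of the open (2-(dimethylamino)ethyl)(methyl)amino chain gives a 2.8-fold higher number from compound 2 to compound 3 (0.45 log units; beyond the scatter). Set against the (3-(dimethylamino)propyl)amino chain, the same ring gives a 1.8-fold higher number from compound 1 to compound 3 (0.26 log units; within the scatter), which stays within the scatter, so compound 1 and compound 3 cannot be separated and the effect of the ring is clear only against compound 2. No supporting data are available to explain this difference.

This change closes the chain into a ring and also brings in a hydrogen-bond donor that the leaving group lacks, and these two differences arrive together, leaving their separate contributions unknown. As far as these compounds go, a 4-methylpiperazin-1-yl group, a piperazine with a methyl on its second nitrogen, would keep the ring without that donor, and how it would read out in this assay remains open, as does the outcome for a morpholine ring or a longer chain at this position.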